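The source may hold more compounds than are shown below. What is called first, only, known or untested is meant among the compounds shown, and "the series" means these compounds.

Compound 2, `CCCCc1cnc(C(CCCC)Cc2ccc(-c3ccccc3C(=O)O)cc2)[nH]1`, is one of two compounds for which a number in an in vitro functional assay on cells for agonist activity at Bombesin receptor subtype-3 (Homo sapiens), read by luminescence and calcium flux (on this read-out lower numbers stand for an effect already at smaller amounts and higher numbers for an effect only at larger amounts of compound), is known. In this assay compound 2 gives 2660 nM. For the measured compounds named here, its only neighbour is compound 1, `CCCCc1cnc(C(C)Cc2ccc(-c3ccccc3C(=O)O)cc2)[nH]1`, which in this assay gives 2760 nM; the two numbers sit within the usual scatter of each other, so neither can be set above the other. Going by the values given here, the one measured step, a 1.0-fold lower number from compound 1 to compound 2 (0.02 log units; within the scatter), shows that lengthening the chain on this saturated carbon left the read-out essentially unchanged.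

Compound 3, `CCCCc1cnc(C(Cc2ccc(-c3ccccc3C(=O)O)cc2)C(C)C)[nH]1`, differs from compound 2 at the same place: isopropyl in place of butyl on a saturated chain carbon bound to an aromatic carbon and a saturated chain carbon. Among the compounds with values here, the only step that bears on this change is a 1.0-fold lower number from compound 1 to compound 2 (0.02 log units; within the scatter), which was within the scatter, and a shortening of the chain by one carbon gives no reason to expect anything different. The step from compound 2 to compound 3 in this assay is therefore expected to be a 1.0-fold higher number from compound 2 to compound 3 (0.01 log units; within the scatter), none beyond the scatter. Compound 3 is estimated to give 2700 nM, with a range from 1300 nM to 5600 nM.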

Compound 3, half-maximal effective concentration: 4620 nM
Estimate against measurement, compound 3: 1.7-fold (0.23 log units) below; the measured number falls inside the stated range.
By their numbers in this assay, from the lowest: compounds 2, 1 and 3 (each within the scatter of the next).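

For the compounds shown here, compound 3 puts isopropyl, a branched group, on the saturated chain carbon bound to an aromatic carbon and a saturated chain carbon, where the earlier compounds carry methyl and butyl. In this assay the steps are a 1.7-fold higher number from compound 2 to compound 3 (0.24 log units; within the scatter) and a 1.7-fold higher number from compound 1 to compound 3 (0.22 log units; within the scatter), so branching at this carbon, like the chain length compared before, gives no difference that can be read among these three compounds. Nothing further is at hand that would bear on these numbers.

The compounds shown leave open whether a group of another kind on this carbon, such as an amine or a cyclohexyl ring, would carry the number beyond the scatter. They also leave open whether a chain longer than butyl would do so.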